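The compounds below may be only part of what the source reports. "The series", "measured", "known", "first", "only" and "open" are said of these compounds alone.

Measured so far:
- compound 1, `CCCCCCCC/C=C/CCCCCCCC(=O)Nc1ccccc1OC` — 8000 nM in an assay on microsomes from intestine for inhibition of acyl-CoA:cholesterol acyltransferase (Oryctolagus cuniculus); a higher number here means a weaker inhibitor, a lower number a stronger inhibitor
- compound 2, `CCCCCCCC/C=C/CCCCCCCC(=O)Nc1ccc(OC)cc1OC` — 3000 nM in this assay

Compound 1 gives the highest of the two numbers in this assay, so it is the weaker inhibitor of the pair; its nearest neighbour is compound 2, and the change is a 2.7-fold lower number from compound 1 to compound 2 (0.43 log units; beyond the scatter). That single step shows that placing a methoxy group on a ring carbon of compound 1 is helpful, but only modestly.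

Compound 3, `CCCCCCCC/C=C/CCCCCCCC(=O)Nc1ccc(F)cc1F`, is reached from compound 1 by a different kind of change: 2,4-difluorophenyl in place of 2-methoxyphenyl on an amide-type nitrogen. Within the data shown here, no measured step covers this exchange of one ring for another on the amide-type nitrogen; the only step available, from compound 1 to compound 2, adds a group rather than swapping the whole 2-methoxyphenyl for 2,4-difluorophenyl, so it offers little guidance. Without a matching precedent, the expectation for compound 3 in this assay is a step of no change at the digits printed from compound 1 to compound 3 (within the scatter), that is, no clear movement beyond the scatter. The estimate for compound 3 is therefore 8000 nM, with a range from 2500 nM to 25000 nM.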

Compound 3, half-maximal inhibitory concentration: 32000 nM
Estimate against measurement, compound 3: 4.0-fold (0.60 log units) below, and the stated range ends below it.
By their numbers in this assay, from the lowest: compound 2; then compound 1; then compound 3.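

In this assay, the ring on the amide-type nitrogen clearly matters: putting 2,4-difluorophenyl in place of 2-methoxyphenyl gives a 4.0-fold higher number from compound 1 to compound 3 (0.60 log units; beyond the scatter), a modest weakening, and putting it in place of 2,4-dimethoxyphenyl gives an 11-fold higher number from compound 2 to compound 3 (1.03 log units; beyond the scatter), a large one. Compound 2 and compound 3 differ only in whether the ring on the amide-type nitrogen is 2,4-dimethoxyphenyl or 2,4-difluorophenyl, and that choice produces the largest step among these compounds, so these two rings are not interchangeable. The compounds carry no measurement that explains why the 2,4-difluorophenyl ring gives the weakest inhibition of the three.

From the compounds shown here alone, it remains open whether a single fluorine, as in 2-fluorophenyl or 4-fluorophenyl, would account for the weakening or whether the effect requires both fluorines together. Going by these compounds, the behaviour of other groups on this ring, such as a chlorine, an amine or a carboxylic acid, also remains open, so these three compounds cannot yet show how far the trend from methoxy to fluorine extends.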